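Dichlorophenyl ethers on a spiro triazine core: notes

The compounds below may be only part of what the source reports. "The series", "measured", "known", "first", "only" and "open" are said of these compounds alone.

Within the data shown here, the series shares one core, carried in compound 1 `NC1=NC2(CCOCC2)N(OCCCOc2ccc(Cl)c(Cl)c2)C(N)=N1`, which is the only member with a number so far: in a functional assay on MDA-MB-231 cells (Homo sapiens) for antiproliferative activity, read by MTT assay, with a stated time of 72 h (on this read-out higher numbers stand for weaker inhibition and lower numbers for stronger inhibition), compound 1 gives 590 nM. Compound 2 `NC1=NC2(CCOCC2)N(OCCCOc2cc(Cl)c(Cl)cc2Cl)C(N)=N1` carries a trichlorophenyl ether, and in this assay compound 2 gives "not determined" (no result reported). Among the measured compounds shown here, compound 3 `Cc1ccc(OCCCON2C(N)=NC(N)=NC23CCOCC3)cc1` carries a 4-methylphenyl ether, and in this assay compound 3 gives "not determined" (no result reported); so compound 3 stands nowhere on the numbers yet and the series offers only the single value of compound 1 as a point of reference.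

Compound 4 `NC1=NC2(CCOCC2)N(OCCCOc2cccc(Cl)c2Cl)C(N)=N1` follows compound 3 by a change at the ether: 2,3-dichlorophenyl in place of 4-methylphenyl on an oxygen on a saturated carbon. For the measured compounds named here, no measured pair tells how much this exchange is worth, so no direction can be read from the data; with compound 3 unplaced, the step in this assay is left open, and the working assumption is a shift no larger than the scatter around the value of compound 1.

Because compound 1 gives 590 nM with a closely related dichlorophenyl ether, compound 4 is expected near 650 nM, estimated within 200 nM to 2500 nM.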

Compound 4, half-maximal inhibitory concentration: 140 nM
Compound 4: middle estimate off by 4.6-fold (0.67 log units), on the high side; the measured number lies below the stated range.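

Exchanging 3,4-dichlorophenyl for 2,3-dichlorophenyl on the ether oxygen gives, in this assay, a 4.2-fold lower number from compound 1 to compound 4 (0.62 log units; beyond the scatter), a step beyond the scatter. The two dichlorophenyl ethers are therefore not interchangeable at this position: with the shared core and the chain unchanged, the placement of the two chlorines alone shifts the read-out, which compound 1 on its own could not show. Nothing at hand bears on why the number moves.

Steps involving compound 2 or compound 3 cannot be read, so the trichlorophenyl and 4-methylphenyl ethers stay unplaced against compound 1 and compound 4. Also open, on these data alone, is whether the lower number of compound 4 would hold with an unsubstituted phenyl ether or with a longer chain between the ether oxygens.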